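Lengthening a Methoxy Group in a Rat Oral Assay

The source may report more compounds than this note shows. Statements on the series, on what has been measured and on what is new or still open speak of the compounds shown alone.

Of the compounds shown here, three share one core and have been tested in a functional assay on the whole organism with Rattus norvegicus as the target, at a dose of 1 mg/kg by the oral route; on this read-out lower numbers stand for a weaker effect and higher numbers for a stronger effect at the one dose given. Compound 1, `Cc1ccc(-c2cc(Cl)cc(C(=O)Nc3nn[nH]n3)n2)cc1`, gives 86%. Compound 2, `COc1cc(C(=O)Nc2nn[nH]n2)nc(-c2ccc(C)cc2)c1`, gives 42%, the lowest of the three numbers. Compound 3, `COc1cc(C(=O)Nc2nn[nH]n2)nc(-c2ccc(N(C)C)cc2)c1`, gives 64%. The step of a number 44 percentage points lower from compound 1 to compound 2 (beyond the scatter) is large and beyond the scatter, coming from methoxy in place of chloro on an aromatic carbon. The step of a number 22 percentage points higher from compound 2 to compound 3 (beyond the scatter) is modest and also beyond the scatter, coming from dimethylamino in place of methyl on an aromatic carbon.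

Compound 4, `CCOc1cc(C(=O)Nc2nn[nH]n2)nc(-c2ccc(C)cc2)c1`, has not yet been measured. It differs from compound 2 by methyl in place of hydrogen on a saturated chain carbon bound to an oxygen on an aromatic ring; cut one bond further out, the difference reads methoxy to ethoxy. Going by the values given here, no measured step changes this same group, so the closest guidance is the step from compound 1 to compound 2, which shows that the substituent at this place matters, but in a different exchange. Among the compounds with values here, with no direct precedent, the step of a number 3 percentage points higher from compound 2 to compound 4 (within the scatter) is expected to stay within the scatter, in no clear direction. Compound 4 is therefore estimated at 45%, with a wide range from 20% to 70% in this assay.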

Compound 4, a percentage reported as inhibition, in the whole organism at one dose (the size of the read-out at that dose, not a potency): 65%
For compound 4 the middle estimate is 20 percentage points below the measured one; low and high end bracket the measured number.
By their numbers in this assay, from the lowest: compound 2; then compounds 3 and 4 (each within the scatter of the next); then compound 1.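

In this assay, the ethoxy group behaves differently from the methoxy group: adding one methyl to the end of the chain gives a number 23 percentage points higher from compound 2 to compound 4 (beyond the scatter), so even one extra carbon at this place can move the read-out at this single dose. The earlier compounds shown here showed only that chloro and methoxy differ here, with a number 44 percentage points lower from compound 1 to compound 2 (beyond the scatter), whereas ethoxy in place of chloro gives a number 21 percentage points lower from compound 1 to compound 4 (beyond the scatter), so an oxygen-linked group at this place does not have one fixed effect and its outcome depends on the chain attached to the oxygen. No measurement shown here explains why adding this methyl changes the read-out.

With only methoxy and ethoxy to compare, the compounds shown leave open whether a longer chain such as propoxy, or a branched one such as isopropoxy, would raise the number further or lower it again. They also leave open whether the change from methoxy to ethoxy has the same effect when dimethylamino stands in place of methyl on an aromatic carbon.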